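The source may hold more compounds than are shown below. What is called first, only, known or untested is meant among the compounds shown, and "the series" means these compounds.

In a functional assay on the whole organism (Hindlimb, strain albino) with Mus musculus as the target, in the maximal electroshock model, with a stated time of 0.5 h (a higher number here means that more compound is needed for the effect, a lower number that less compound is needed), compound 2 (`CC(=O)N1N=C(Nc2nc3ccccc3s2)CC1c1ccc(Cl)cc1`) gives 209 umol/kg. Compound 3 (`CC(=O)N1N=C(Nc2nc3ccc([N+](=O)[O-])cc3s2)CC1c1ccc(Cl)cc1`) gives 132 umol/kg, which is within the scatter of compound 2. Compound 1 (`COc1ccc(C2CC(Nc3nc4ccc(C)cc4s3)=NN2C(C)=O)cc1O`) gives 73.9 umol/kg, a lower number than compound 2 and beyond the scatter.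

The next compound, compound 4 (`COc1ccc(C2CC(Nc3nc4ccccc4s3)=NN2C(C)=O)cc1O`), carries 3-hydroxy-4-methoxyphenyl in place of 4-chlorophenyl on a saturated ring carbon.

For the measured compounds named here, no measured step covers this exchange directly. Going by the values given here, the one measured step, a 1.6-fold lower number from compound 2 to compound 3 (0.20 log units; within the scatter), concerns an aromatic carbon rather than the saturated ring carbon, and it says little here. Compound 1 shares the 3-hydroxy-4-methoxyphenyl group with compound 4 but also differs from compound 2 elsewhere, so compound 1, at 73.9 umol/kg, is only an indirect guide. A moderate move towards a lower number is therefore expected, though it may not clear the scatter. The expected step is a 2.2-fold lower number from compound 2 to compound 4 (0.34 log units; beyond the scatter). Compound 4 is estimated at 95 umol/kg, with an expected range of 45 umol/kg to 200 umol/kg.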

Compound 4, dose for half-maximal effect: 259 umol/kg
The estimate for compound 4 lay 2.7-fold (0.44 log units) below the measured number; measured number outside the range, above it.
By their numbers in this assay, from the lowest: compounds 1, 3, 2 and 4 (each within the scatter of the next, the first and the last beyond it).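

In this assay the exchange itself gives a 1.2-fold higher number from compound 2 to compound 4 (0.09 log units; within the scatter), so on this saturated ring carbon the assay does not separate 3-hydroxy-4-methoxyphenyl from 4-chlorophenyl when the rest of the molecule is the same. For the compounds shown here, with 3-hydroxy-4-methoxyphenyl held in place, the single change on the aromatic carbon, hydrogen in place of methyl, gives a 3.5-fold higher number from compound 1 to compound 4 (0.54 log units; beyond the scatter), so the low number of compound 1 goes with its methyl and not with the 3-hydroxy-4-methoxyphenyl group alone. Nothing measured here accounts for either step.

As far as these compounds go, it remains open whether the methyl would give a similar step alongside 4-chlorophenyl. From the compounds shown here alone, it is also open how this assay would respond to a phenyl ring carrying an amine or a carboxylic acid on the saturated ring carbon.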